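The source may report more compounds than this note shows. Statements on the series, on what has been measured and on what is new or still open speak of the compounds shown alone.

Series notes. In an assay on isolated protein for inhibition of serine protease 1 (Bos taurus) (a lower number here means a stronger inhibitor, a higher number a weaker inhibitor), the three measured compounds stand as follows.

Compound 1 `Cc1c(F)c(Oc2cccc(C(=N)N)c2)nc(Oc2cccc([N+](=O)[O-])c2)c1F` gives > 5000 nM, which is a limit of this assay and not a number.
Compound 2 `Cc1c(F)c(Oc2cccc(OC(C)C)c2)nc(Oc2cccc(C(=N)N)c2)c1F` gives 2900 nM.
Compound 3 `Cc1c(F)c(Oc2cccc(CC(N)=O)c2)nc(Oc2cccc(C(=N)N)c2)c1F` gives > 5000 nM, again a limit and not a number.

Compound 3 therefore stands at the limit, and one further value shown is also a limit (the limit of > 5000 nM in this assay, at which 2 of the 3 values shown sit). Its step from compound 2 reads an at least 1.7-fold higher number from compound 2 to compound 3 (0.23 log units; that floor lies within the scatter), its step from compound 1 reads a step that the two limits leave unreadable from compound 1 to compound 3. The whole series sits at the weak end of this assay.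

Compound 4 `Cc1c(F)c(Oc2cccc(C(=N)N)c2)nc(Oc2ccc(Cl)c(N(C)C)c2)c1F` is not yet measured. It differs from compound 3 in 4-chloro-3-(dimethylamino)phenyl in place of 3-(carbamoylmethyl)phenyl on an oxygen on an aromatic ring. For the measured compounds named here, none of the measured steps changes the group on this oxygen in the same way; what is known concerns the nitro, isopropoxy and carbamoylmethyl groups on the aromatic carbon, and the only readable step there, an at least 1.7-fold lower number from compound 1 to compound 2 (0.23 log units; that floor lies within the scatter), has its floor within the scatter. No step beyond the scatter is therefore expected in this assay from compound 3 to compound 4 in either direction, and the expected step is an at least 1.2-fold lower number from compound 3 to compound 4 (0.09 log units; that floor lies within the scatter). Compound 4 is estimated at 4000 nM, expected between 1500 nM and 10000 nM, with a fair chance that this assay again reports only a limit.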

Compound 4, inhibition constant: 1000 nM
Compound 4: the middle estimate sits 4.0-fold (0.60 log units) above what was measured, and the stated range ends above it.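

In this assay, for the compounds shown here, the aryl group on this oxygen is the first place where a change is printed beyond the scatter: a 2.9-fold lower number from compound 2 to compound 4 (0.46 log units; beyond the scatter). The steps from the other two compounds are an at least 5.0-fold lower number from compound 3 to compound 4 (0.69 log units; beyond the scatter) and an at least 5.0-fold lower number from compound 1 to compound 4 (0.69 log units; beyond the scatter), and both are only floors, so their true size stays unread: the limit of > 5000 nM in this assay, at which 2 of the 4 values shown sit. Compound 4 is thus the only compound of the four with steps to all the others beyond the scatter, which makes it the strongest inhibitor shown and sets 4-chloro-3-(dimethylamino)phenyl ahead of the nitro, isopropoxy and carbamoylmethyl variants.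

The chloro and dimethylamino groups enter together, so the compounds shown do not tell which of them carries the step; a phenyl with only the chloro group or only the dimethylamino group would separate the two. On these data alone, how a primary amine, a carboxylic acid or a longer chain in place of the dimethylamino group would read in this assay also stays open.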